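Chain length at the indole carbon and leukotriene receptor antagonism

This account rests on a few compounds, and the source may have more. Where it says the series, first, only, none or still open, it means among the compounds named here.

Measured compounds:
compound 1, `Cc1c(Cl)cccc1CCCCOc1ccc(C#Cc2cccc3c(CCCC(=O)O)c(C)n(CCC(=O)O)c23)cc1`, 17 nM
compound 2, `Cc1c(Cl)cccc1CCCCOc1ccc(C#Cc2cccc3c(CCCC(=O)O)c(C)n(CCCCC(=O)O)c23)cc1`, 56 nM
compound 3, `Cc1c(Cl)cccc1CCCCOc1ccc(C#Cc2cccc3c(CC(=O)O)c(C)n(CCCCC(=O)O)c23)cc1`, 65 nM

All three compounds share one core and differ only in the two acid-bearing chains. In a functional assay on CHO-K1 cells for antagonist activity at cysteinyl leukotriene receptor 1 (Homo sapiens), read by fluorescence and calcium flux, with stated times of 30 min and 1 h (a higher number here means a weaker inhibitor, a lower number a stronger inhibitor), compound 1 gives 17 nM. Lengthening the chain on the aromatic nitrogen gave a 3.3-fold higher number from compound 1 to compound 2 (0.52 log units; beyond the scatter). Shortening the other chain then gave a 1.2-fold higher number from compound 2 to compound 3 (0.06 log units; within the scatter), so compound 3 and compound 2 cannot be told apart on these numbers, while compound 3 sits well apart from compound 1, which has the lower number.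

Compound 4, `Cc1c(Cl)cccc1CCCCOc1ccc(C#Cc2cccc3c(CCC(=O)O)c(C)n(CCCCC(=O)O)c23)cc1`, keeps the longer chain on the aromatic nitrogen and differs from compound 3 by carboxymethyl in place of carboxy on a saturated chain carbon bound to an aromatic carbon. Within the data shown here, the one measured step that bears on this position is the change from compound 2 to compound 3, and that step, a 1.2-fold higher number from compound 2 to compound 3 (0.06 log units; within the scatter), stayed within the scatter although it spanned two carbons. Compound 4 lies between those two chain lengths, so the expected step in this assay is none beyond the scatter, with at most a slight drift toward a lower number.

The expected step is a 1.2-fold lower number from compound 3 to compound 4 (0.07 log units; within the scatter). Compound 4 is therefore estimated at 55 nM, within a range from 25 nM to 120 nM.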

Compound 4, half-maximal inhibitory concentration: 25 nM
For compound 4 the middle estimate is 2.2-fold (0.34 log units) above the measured one; low and high end bracket the measured number.
By their numbers in this assay, from the lowest: compounds 1 and 4 (each within the scatter of the next); then compounds 2 and 3 (each within the scatter of the next).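

Among these compounds, with the longer chain on the aromatic nitrogen held fixed, carboxymethyl in place of carboxy on a saturated chain carbon bound to an aromatic carbon gives in this assay a 2.6-fold lower number from compound 3 to compound 4 (0.41 log units; beyond the scatter), so this place responds to chain length in a way the earlier compounds gave no sign of. Compound 4 also stands apart from the compound with 2-carboxyethyl at this place, with a 2.2-fold lower number from compound 2 to compound 4 (0.35 log units; beyond the scatter), which means the response across compound 2, compound 3 and compound 4 is no steady trend: the middle chain carries the lowest number. The two ends of the series, compound 2 and compound 3, lie within the scatter of each other, and their agreement had hidden this dip at the intermediate length.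

From the compounds shown here alone, it remains open whether the same preference holds with the shorter chain on the aromatic nitrogen found in compound 1, and how a longer chain, an amide or a tetrazole in place of the carboxylic acid at this place would read. Nothing available here explains why the intermediate chain differs from its two neighbours.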